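This account rests on a few compounds, and the source may have more. Where it says the series, first, only, none or still open, it means among the compounds named here.

Working notes on the series. The shared core, seen in compound 2 `Cc1csn(-c2ccccc2)c1=O` and compound 3 `COCc1csn(-c2ccccc2)c1=O`, carries a methyl or a methoxymethyl group. In an assay for inhibition of histone acetyltransferase KAT2B (Homo sapiens) (a higher number here means a weaker inhibitor, a lower number a stronger inhibitor), compound 2 gives 32000 nM and compound 3 gives 102000 nM. Compound 1 `O=C(Nc1ccccc1)OCc1cc(=O)n(-c2ccccc2)s1` reaches only the limit > 200000 nM in this assay, a limit and not a number (the limit of > 200000 nM in this assay, at which 1 of the 3 values shown sits). Compound 3 therefore holds the highest of the two numbers, with a 3.2-fold higher number from compound 2 to compound 3 (0.50 log units; beyond the scatter).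

Compound 4 `[N-]=[N+]=NCc1csn(-c2ccccc2)c1=O` differs from compound 3 by azido in place of methoxy on a saturated chain carbon bound to an aromatic carbon. Among the measured compounds shown here, no measured step swaps one group for another at this position; the only step touching it, a 3.2-fold higher number from compound 2 to compound 3 (0.50 log units; beyond the scatter), is modest. A change of similar size, in either direction, is expected: for compound 4 in this assay the estimate is 70000 nM, range 20000 nM to 250000 nM, a step of a 1.5-fold lower number from compound 3 to compound 4 (0.16 log units; within the scatter).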

Compound 4, half-maximal inhibitory concentration: 42700 nM
Compound 4: the middle estimate sits 1.6-fold (0.21 log units) above what was measured; the range from low to high includes it.
By their numbers in this assay, from the lowest: compounds 2 and 4 (each within the scatter of the next); then compound 3. At a limit, above all of these: compound 1.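

Azido in place of methoxy gives a 2.4-fold lower number from compound 3 to compound 4 (0.38 log units; beyond the scatter) in this assay and is the first swap of one group for another that can be read at this position. Azido in place of hydrogen gives a 1.3-fold higher number from compound 2 to compound 4 (0.13 log units; within the scatter) and so the higher number of compound 3 does not follow from every replacement of that hydrogen.

From the compounds shown here alone, whether an amine or a carboxylic acid on this saturated chain carbon would match compound 2 or move the number beyond the scatter stays open. The data shown give no reason for either step.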